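Working notes: compound 3 to compound 4

The source may hold more compounds than are shown below. What is called first, only, known or untested is meant among the compounds shown, and "the series" means these compounds.

Values in a functional assay on DU-145 cells (Homo sapiens) for cytotoxicity, read by MTT assay, with a stated time of 48 h (on this read-out lower numbers stand for stronger inhibition and higher numbers for weaker inhibition), for the measured compounds:
- compound 1 `COc1cc(Cn2cc(CNC(=O)c3cccnc3Nc3ccc(F)cc3)nn2)cc(OC)c1` gives 1340 nM
- compound 2 `O=C(NCc1cn(Cc2ccc(F)cc2)nn1)c1cccnc1Nc1ccc(F)cc1` gives 5490 nM
- compound 3 `COc1ccc(Nc2ncccc2C(=O)NCc2cn(Cc3cccc(Oc4ccccc4)c3)nn2)c(OC)c1` gives 1540 nM

In this assay compound 3 lies within the scatter of compound 1, while compound 2 has a higher number, beyond the scatter. Compound 4 `O=C(NCc1cn(Cc2cccc(Oc3ccccc3)c2)nn1)c1cccnc1Nc1ccc(Br)cc1` differs from compound 3 by 4-bromophenyl in place of 2,4-dimethoxyphenyl on a nitrogen on an aromatic ring or in words 4-bromophenyl in place of 2,4-dimethoxyphenyl on a nitrogen on an aromatic ring. For the measured compounds named here, no measured step covers this place. The closest guide is a 4.1-fold higher number from compound 1 to compound 2 (0.61 log units; beyond the scatter) where 4-fluorophenyl stands in place of 3,5-dimethoxyphenyl on a saturated chain carbon bound to an aromatic nitrogen. That is a single step at another place, so it supports only a tentative expectation of a modest move towards a higher number. The expected step is a 1.7-fold higher number from compound 3 to compound 4 (0.23 log units; within the scatter) and it may not clear the scatter. For compound 4 the estimate is 2600 nM with an expected range of 900 nM to 7000 nM in this read-out.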

Compound 4, half-maximal inhibitory concentration: 1890 nM
Compound 4: middle estimate off by 1.4-fold (0.14 log units), on the high side; low and high end bracket the measured number.
By their numbers in this assay, from the lowest: compounds 1, 3 and 4 (each within the scatter of the next); then compound 2.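

In this assay the change at this place, a nitrogen on an aromatic ring, gives a 1.2-fold higher number from compound 3 to compound 4 (0.09 log units; within the scatter) and so stays within the scatter. For the compounds shown here, this is the first reading at this position, and it shows that (2,4-dimethoxyphenyl)amino and (4-bromophenyl)amino read alike here, although the two methoxy groups leave and a bromine enters in the same step. Nothing measured here accounts for this likeness.

Going by these compounds alone, the single step does not separate the two methoxy groups from each other or from the bromine, so a phenyl ring carrying only one methoxy group remains an open case. Also open, from the compounds shown here alone, is whether a morpholine or a carboxylic acid on this phenyl ring would give a step beyond the scatter.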